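The source may hold more compounds than are shown below. What is called first, only, known or untested is meant among the compounds shown, and "the series" means these compounds.

Compound 2 `CC#C[C@H]1CN(S(=O)(=O)c2ccc(N)nc2)CCN1c1ccc(C(O)(CC#N)C(F)(F)F)cc1` is the reference point for this step. In an ADME assay (liver) for metabolic stability, with Liver microsome (Rattus norvegicus) as the target, using microsomes and NADPH, with a stated time of 30 min (a lower number here means slower removal, a higher number faster removal of the compound), compound 2 gives 57 mL.min-1.g-1, the lowest of the two numbers recorded; the nearest is compound 3 `CC#C[C@H]1CN(S(=O)(=O)c2ccc(N)nc2)CCN1c1ncc(C(C)(O)C(F)(F)F)s1`, which in this assay gives 87 mL.min-1.g-1, a gap within the scatter. Compound 1 `CC#C[C@H]1CN(S(=O)(=O)c2ccc(N)nc2)CCN1c1ccccc1` gives a limit in this assay, namely > 399 mL.min-1.g-1. Going by the values given here, the single measured step, an at least 7.0-fold lower number from compound 1 to compound 2 (0.84 log units; beyond the scatter), concerns adding the very group that compound 4 now loses, so it bears only indirectly on the present change. Compound 4 `CC#C[C@H]1CN(S(=O)(=O)c2ccc(N)nc2)CCN1c1ccc(S(=N)(=O)C2CC2)cc1` differs from compound 2 by a group of 6 heavy atoms (3 carbon, 1 nitrogen, 1 oxygen, 1 sulfur; one three-membered non-aromatic ring of carbon only) in place of a group of 9 heavy atoms (4 carbon, 1 nitrogen, 1 oxygen, 3 fluorine; no ring), on an aromatic carbon. Among the compounds with values here, no measured step exchanges one such group for another, so the expected step of a 1.4-fold higher number from compound 2 to compound 4 (0.15 log units; within the scatter) is modest and not clearly beyond the scatter. Compound 4 is estimated at 80 mL.min-1.g-1, within 35 mL.min-1.g-1 to 190 mL.min-1.g-1.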

Compound 4, intrinsic clearance in microsomes: 23 mL.min-1.g-1
Compound 4: the middle estimate sits 3.5-fold (0.54 log units) above what was measured; the whole stated range lies above it.
By their numbers in this assay, from the lowest: compound 4; then compounds 2 and 3 (each within the scatter of the next). At a limit, above all of these: compound 1.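

In this assay, the sulfur-bearing group with its three-membered ring, on the aromatic carbon, does better than the fluorine-bearing group it replaces, with a 2.5-fold lower number from compound 2 to compound 4 (0.39 log units; beyond the scatter). Measured against the unsubstituted phenyl ring, the change is larger, with an at least 17-fold lower number from compound 1 to compound 4 (1.23 log units; beyond the scatter). That second step is only a bound, as compound 1 stands at a limit: the limit of > 399 mL.min-1.g-1 in this assay, at which 1 of the 4 values shown sits.

Going by these compounds, whether the lower number survives with a methyl or cyclopentyl group on the sulfur remains open. So does the effect of an amine or a carboxylic acid at this place.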